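From bromo to trifluoromethyl on compound 3

The compounds below may be only part of what the source reports. "The series", "measured", "known", "first", "only" and "open" are said of these compounds alone.

Measured so far in an ADME assay on L6 cells (Rattus norvegicus) for cytotoxicity, read by resazurin assay, with a stated time of 72 h; a lower number here means a stronger inhibitor, a higher number a weaker inhibitor
compound 1 `OC(c1ccc(Cl)cc1)(c1ccc(C(F)(F)F)cc1)c1cncnc1` gives 66800 nM
compound 2 `Cc1ccc(C(O)(c2ccc(Cl)cc2)c2cccnc2)cc1` gives 61000 nM
compound 3 `OC(c1ccc(Cl)cc1)(c1ccc(Br)cc1)c1cccnc1` gives 57000 nM

Compound 3 stands level with the other two, as all three values lie within the scatter of one another. Compound 4 `OC(c1ccc(Cl)cc1)(c1ccc(C(F)(F)F)cc1)c1cccnc1` has trifluoromethyl in place of bromo on an aromatic carbon, para to a large group: trifluoromethyl in place of bromo on an aromatic carbon. The closest measured change, bromo in place of methyl on an aromatic carbon, is a 1.1-fold lower number from compound 2 to compound 3 (0.03 log units; within the scatter). Compound 1 already carries trifluoromethyl and gives 66800 nM, although it differs from compound 4 elsewhere. On this evidence, no step beyond the scatter is expected in this assay, in either direction. The estimated step is a 1.1-fold higher number from compound 3 to compound 4 (0.02 log units; within the scatter), which would lie within the scatter. For compound 4 the expected value is 60000 nM, with an estimated range of 35000 nM to 100000 nM.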

Compound 4, half-maximal inhibitory concentration: 56400 nM
For compound 4 the middle estimate is 1.1-fold (0.03 log units) above the measured one, and the stated range covers the measured number.
By their numbers in this assay, from the lowest: compounds 4, 3, 2 and 1 (each within the scatter of the next).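

In this assay, trifluoromethyl in place of bromo on an aromatic carbon, para to a large group, leaves the reading flat (a 1.0-fold lower number from compound 3 to compound 4 (0.00 log units; within the scatter)), and the same holds for trifluoromethyl in place of methyl (a 1.1-fold lower number from compound 2 to compound 4 (0.03 log units; within the scatter)). Methyl, bromo and trifluoromethyl at this position therefore read alike here. With trifluoromethyl held fixed, pyridin-3-yl in place of pyrimidin-5-yl also stays within the scatter (a 1.2-fold lower number from compound 1 to compound 4 (0.07 log units; within the scatter)). No supporting evidence is available to explain these results.

The compounds shown leave open whether an amine or a carboxylic acid at this position would give a step beyond the scatter.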